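Hydroxy-for-methoxy swap on the pyrazole aryl series

The source may report more compounds than this note shows. Statements on the series, on what has been measured and on what is new or still open speak of the compounds shown alone.

Measured compounds:
- compound 1, `Cc1cc(O)cc(-c2nn(CC#N)cc2-c2ccnc(-c3ccc(Oc4ccccc4)cc3)c2)c1`: -41%
- compound 2, `COc1cc(C)cc(-c2nn(CC#N)cc2-c2ccnc(-c3ccc(N(C)C)cc3)c2)c1`: 23%

In a functional assay on EKVX cells (Homo sapiens) for cytotoxicity, read by sulforhodamine B assay, with a stated time of 48 h, tested at 10 uM (on this read-out lower numbers stand for a stronger effect and higher numbers for a weaker effect at the one concentration tested), compound 2 gives 23%, the highest of the two numbers at hand. Within the data shown here, its nearest neighbour is compound 1, which in this assay gives -41%, a number lower by a margin beyond the scatter; compound 1 differs from compound 2 at two places, so no single step between them can be read.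

Compound 3, `Cc1cc(O)cc(-c2nn(CC#N)cc2-c2ccnc(-c3ccc(N(C)C)cc3)c2)c1`, is not yet measured in this assay. It differs from compound 2 in one place: hydrogen in place of methyl on an oxygen on an aromatic ring. Among the measured compounds shown here, the only measured compound bearing the hydroxy group, compound 1, gives the lower of the two numbers, but its other aryl arm differs as well, so that comparison carries no clean weight.

Expectation for compound 3: a step toward a lower number, of moderate size, beyond the scatter but short of the gap between compound 2 and compound 1; this is estimated as a number 23 percentage points lower from compound 2 to compound 3 (beyond the scatter). Compound 3 is therefore expected to give about 0%, with a range from -40% to 35%.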

Compound 3, a percentage reported as activity, at one concentration (the size of the read-out at that concentration, not a potency): -1%
For compound 3 the middle estimate is 1 percentage points above the measured one, and the stated range covers the measured number.
By their numbers in this assay, from the lowest: compound 1; then compound 3; then compound 2.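

In this assay, the change from methoxy to hydroxy on the aromatic ring can now be read alone, with the dimethylamino arm held constant: hydrogen in place of methyl on the oxygen gives a number 24 percentage points lower from compound 2 to compound 3 (beyond the scatter), a modest step beyond the scatter. Compound 3 also isolates the other arm with the hydroxy group held constant, and dimethylamino in place of phenoxy on an aromatic carbon gives a number 40 percentage points higher from compound 1 to compound 3 (beyond the scatter), a large step, so the gap between the two earlier compounds now resolves into two single changes, with hydroxy and phenoxy each going with the lower number in its own pair. No measurement is at hand that bears on what lies behind either step.

The compounds shown leave open whether the step at the oxygen keeps its size when phenoxy occupies the other arm, since that pairing offers only one of its two partners here. They also leave open how an amine or a longer chain such as ethoxy at this position would compare with hydroxy and methoxy, as only these two groups can be read there so far.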